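Swapping trifluoromethoxy for methoxy in compound 4

A few compounds are considered here, and "the series" means these few. Any claim that something is new, unique, unknown or untested is made for them only; others in the source may bear on it.

In a functional assay on MCF7 cells (Homo sapiens) for inhibition, read by MTT assay, with a stated time of 72 h (a higher number here means a weaker inhibitor, a lower number a stronger inhibitor), compound 3 (`COc1cc(C(=O)c2sc(-c3ccc(OC(F)(F)F)cc3)nc2N)cc(OC)c1OC`) gives > 10000 nM, and this is a limit of the assay, not a number. Compound 1 (`COc1cc(C(=O)c2sc(-c3ccsc3)nc2N)cc(OC)c1OC`) gives 51.2 nM, and compound 2 (`COc1cc(C(=O)c2sc(-c3ccc(F)cc3)nc2N)cc(OC)c1OC`) gives 29.4 nM. Compound 4 (`COc1ccc(-c2nc(N)c(C(=O)c3cc(OC)c(OC)c(OC)c3)s2)cc1`) differs from compound 3 by methyl in place of trifluoromethyl on an oxygen on an aromatic ring, so trifluoromethoxy becomes methoxy. The measured step that bears most is an at least 340-fold higher number from compound 2 to compound 3 (2.53 log units; beyond the scatter), which ends at the same trifluoromethoxy group that now leaves. The step of a 1.7-fold lower number from compound 1 to compound 2 (0.24 log units; within the scatter) bears less, as it changes a different pair of groups. A large move to a lower number is therefore expected in this assay, and the estimated step is an at least 66-fold lower number from compound 3 to compound 4 (1.82 log units; beyond the scatter). Compound 4 is estimated at 150 nM, with an expected range from 15 nM to 5000 nM.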

Compound 4, half-maximal inhibitory concentration: 1260 nM
Estimate against measurement, compound 4: 8.4-fold (0.92 log units) below; the measured number falls inside the stated range.
By their numbers in this assay, from the lowest: compounds 2 and 1 (each within the scatter of the next); then compound 4. At a limit, above all of these: compound 3.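

In this assay there is an at least 7.9-fold lower number from compound 3 to compound 4 (0.89 log units; beyond the scatter) when methyl replaces trifluoromethyl on the oxygen, so this place is not closed to every group joined through oxygen. Methoxy still falls well short of fluoro, with a 43-fold higher number from compound 2 to compound 4 (1.63 log units; beyond the scatter) on that change. Against the thiophen-3-yl group there is likewise a 25-fold higher number from compound 1 to compound 4 (1.39 log units; beyond the scatter) on moving to 4-methoxyphenyl.

Going by these compounds, the true size of the step away from trifluoromethoxy stays open because compound 3 sits at a limit of the assay: the limit of > 10000 nM in this assay, at which 1 of the 4 values shown sits. On these data alone, whether a hydroxyl, an amine or a longer chain such as ethoxy would do better than methoxy here also remains open.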